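The source may hold more compounds than are shown below. What is called first, only, known or untested is meant among the compounds shown, and "the series" means these compounds.

Measured compounds in a functional assay on HeLa cells (Homo sapiens) for cytotoxicity, read by WST assay, with a stated time of 48 h; a lower number here means a stronger inhibitor, a higher number a weaker inhibitor:
- compound 1, `COc1cc(C(c2ccc(O)c(OC)c2)[C@H](C)[C@H](C)CF)ccc1O`: 75000 nM
- compound 2, `COC[C@H](C)[C@@H](C)C(c1ccc(O)c(OC)c1)c1ccc(O)c(OC)c1`: 77000 nM
- compound 3, `COc1cc(C(c2ccc(O)c(OC)c2)[C@H](CC(C)C)C(C)C)ccc1O`: 8200 nM

On these numbers compound 1 stands second highest of three. Its nearest neighbour is compound 2, a 1.0-fold higher number from compound 1 to compound 2 (0.01 log units; within the scatter); the furthest is compound 3, a 9.1-fold lower number from compound 1 to compound 3 (0.96 log units; beyond the scatter).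

The step under consideration goes from compound 1 to compound 4, `COc1cc(C(c2ccc(O)c(OC)c2)[C@@H](CO)C(C)C)ccc1O`, not yet measured. The change: 1-(hydroxymethyl)-2-methylpropyl in place of 2-(fluoromethyl)-1-methylpropyl on a saturated chain carbon bound to two aromatic carbons. For the measured compounds named here, two measured steps bear on it. The exchange from compound 1 to compound 2 swaps the fluorine of the chain for an oxygen without moving the number, a 1.0-fold higher number from compound 1 to compound 2 (0.01 log units; within the scatter). The exchange to compound 3, a longer chain without a heteroatom, gives a 9.1-fold lower number from compound 1 to compound 3 (0.96 log units; beyond the scatter); compound 2 to compound 3 gives much the same, a 9.4-fold lower number from compound 2 to compound 3 (0.97 log units; beyond the scatter). Compound 4 keeps a six-heavy-atom chain carrying a heteroatom, now one hydrogen-bond donor and one acceptor, so the expected step is small, a 1.1-fold higher number from compound 1 to compound 4 (0.03 log units; within the scatter), with no clear direction beyond the scatter. In this assay compound 4 is estimated at 80000 nM, range 30000 nM to 200000 nM.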

Compound 4, half-maximal inhibitory concentration: > 100000 nM
Compound 4: only a limit was reported (the forecaster's own chance of this, stated with the estimate: 20%); at least 1.2-fold (0.09 log units) between middle value and limit.
By their numbers in this assay, from the lowest: compound 3; then compounds 1 and 2 (each within the scatter of the next). At a limit, above all of these: compound 4.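

In this assay compound 4 carries only a limit, not a number: the limit of > 100000 nM in this assay, at which 1 of the 4 values shown sits. The floors are an at least 1.3-fold higher number from compound 1 to compound 4 (0.12 log units; that floor lies within the scatter) and an at least 1.2-fold higher number from compound 2 to compound 4 (0.11 log units; that floor lies within the scatter), so neither step separates its pair, and the 1-(hydroxymethyl)-2-methylpropyl chain cannot be placed apart from the fluorine-bearing or methoxy-bearing chain on the saturated chain carbon bound to two aromatic carbons. Against the 1-isopropyl-3-methylbutyl chain the step is clear, an at least 12-fold higher number from compound 3 to compound 4 (1.08 log units; beyond the scatter), so among the compounds shown all three heteroatom-bearing chains sit apart from the one chain without a heteroatom.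

From the compounds shown here alone, the actual value of compound 4 stays open, as does whether the gap follows the heteroatom or the chain length, which change together in compound 3. An all-carbon chain of the size of the 2-(fluoromethyl)-1-methylpropyl group, or a longer chain ending in a hydroxyl or an amine, would separate the two.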